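Methyl added to the anilino group of compound 1

The compounds below may be only part of what the source reports. "The series", "measured", "known", "first", "only" and "open" are said of these compounds alone.

Measured so far in a functional assay on MOLT-4 cells (Homo sapiens) for antiproliferative activity, read by cell counting, with a stated time of 2 days; on this read-out higher numbers stand for weaker inhibition and lower numbers for stronger inhibition:
- compound 1 `COc1cc(C(=O)c2sc(Nc3ccccc3)nc2N)cc(OC)c1OC` gives 6 nM
- compound 2 `COc1ccc(C(=O)c2sc(Nc3ccccc3)nc2N)cc1OC` gives 5500 nM

Compound 1 holds the lower of the two numbers, which makes it the stronger inhibitor so far in this assay of this pair. Next comes compound 3 `COc1cc(C(=O)c2sc(Nc3ccc(C)cc3)nc2N)cc(OC)c1OC` with the change methyl in place of hydrogen on an aromatic carbon in the anilino group, methyl in place of hydrogen on an aromatic carbon, para to a large group. Among the measured compounds shown here, the only measured step is a 920-fold higher number from compound 1 to compound 2 (2.96 log units; beyond the scatter) and it is large, yet it removes a methoxy and touches nothing on the anilino group. For the measured compounds named here, it offers little guidance here, since no measured step covers this change. No shift beyond the scatter is expected in this assay and no firm direction. The expected step is a 1.3-fold higher number from compound 1 to compound 3 (0.12 log units; within the scatter) on this estimate. For compound 3 the estimated value is 8 nM with an expected range from 2 nM to 40 nM on this read-out.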

Compound 3, half-maximal inhibitory concentration: 21 nM
Beside the measured number, compound 3's estimate is 2.6-fold (0.42 log units) below it, within the range that was stated.
By their numbers in this assay, from the lowest: compound 1; then compound 3; then compound 2.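

In this assay, the anilino group, untouched by the earlier step, responds to substitution: methyl in place of hydrogen on the aromatic carbon, para to a large group, gives a 3.5-fold higher number from compound 1 to compound 3 (0.54 log units; beyond the scatter), a modest change but beyond the scatter. Compound 3 still stands at 21 nM, so this added methyl costs far less than removing the methoxy, which gives a 920-fold higher number from compound 1 to compound 2 (2.96 log units; beyond the scatter). No measured property of these compounds bears on the reason for this shift.

From the compounds shown here alone, a single substituent at this place gives no trend, so it remains open whether a fluorine, a hydroxyl, an amine or a carboxylic acid on the same carbon would shift the number in the same direction. Going by these compounds, the effect of a longer chain such as ethyl or propyl on this carbon also remains open, as does that of a methyl elsewhere on the same ring.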